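One Stereocentre Reversed at a Saturated Ring Carbon

A few compounds are considered here, and "the series" means these few. Any claim that something is new, unique, unknown or untested is made for them only; others in the source may bear on it.

Compound 1 `Cc1ccc(/C=C/[C@]2(C)CC[C@@](C)(/C=C/C3=C[C@H](O)[C@](C)(O)C[C@@H]3O)O2)cc1`: 10700 nM
Compound 2 `Cc1ccc(/C=C/[C@@]2(C)CC[C@](C)(/C=C/C3=C[C@H](O)[C@](C)(O)C[C@@H]3O)O2)cc1`: 9300 nM

In a functional assay on HeLa cells (Homo sapiens) for inhibition, read by MTT assay, with a stated time of 72 h (a lower number here means a stronger inhibitor, a higher number a weaker inhibitor), compound 1 gives 10700 nM and compound 2 gives 9300 nM. For the measured compounds named here, compound 2 has the lowest of the two numbers, but the single step recorded here, a 1.2-fold lower number from compound 1 to compound 2 (0.06 log units; within the scatter), stays within the scatter, so the two compounds cannot be ordered; the step rests on (the fact that compounds 1 and 2 differ only in the configuration as drawn).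

Compound 3 `Cc1ccc(/C=C/[C@@]2(C)CC[C@@](C)(/C=C/C3=C[C@H](O)[C@](C)(O)C[C@@H]3O)O2)cc1` is the next member of the series. (the two compounds have the same atoms and bonds and differ only in configuration as drawn: 1 of 7 stereo elements differ; a stereocentre at a saturated ring carbon is drawn R in compound 2 and S in compound 3). Going by the values given here, the only measured step that bears on this change is a 1.2-fold lower number from compound 1 to compound 2 (0.06 log units; within the scatter), where two stereo elements were reversed together and the number did not move beyond the scatter. A single reversal at a saturated ring carbon is therefore expected to leave the inhibition essentially where compound 2 stands, with no step beyond the scatter. Compound 3 is expected to give 10000 nM in this assay, with a range from 4500 nM to 22000 nM. The expected step is a 1.1-fold higher number from compound 2 to compound 3 (0.03 log units; within the scatter).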

Compound 3, half-maximal inhibitory concentration: 31100 nM
For compound 3 the middle estimate is 3.1-fold (0.49 log units) below the measured one, and the stated range ends below it.
By their numbers in this assay, from the lowest: compounds 2 and 1 (each within the scatter of the next); then compound 3.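

A single reversal at a saturated ring carbon can move the number in this assay, which the earlier pair could not show: the record gives a 3.3-fold higher number from compound 2 to compound 3 (0.52 log units; beyond the scatter), and a 2.9-fold higher number from compound 1 to compound 3 (0.46 log units; beyond the scatter). Compound 3 differs from each of the other two at one stereocentre, whereas the pair reversed at two stereocentres stays within the scatter, so among these three compounds the two centres do not act independently. This comparison involves configuration alone: the fact that compounds 2 and 3 differ only in the configuration as drawn

From the compounds shown here alone, what the remaining combination of these two stereocentres would give in this assay stays open, so it cannot be said whether the higher number belongs to compound 3 alone or to both mixed arrangements. Also open, going by these compounds, is whether the same dependence on configuration would hold with an amine or a carboxylic acid on the shared core.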